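The compounds below may be only part of what the source reports. "The series", "measured", "known", "first", "only" and "open" are said of these compounds alone.

Compound 1 `CCn1c(C(=O)NC2(CO)CC2)ccc1C(CC)(CC)c1ccc(OCS(=O)(=O)c2ccccc2)c(C)c1` carries a 1-(hydroxymethyl)cyclopropyl group on an amide-type nitrogen. In a functional assay on MCF7 cells (Homo sapiens) for antiproliferative activity, read by MTT assay, with a stated time of 24 h (a lower number here means a stronger inhibitor, a higher number a weaker inhibitor), compound 1 gives 28800 nM. Two close analogues carry acid-bearing chains in its place: compound 2 `CCn1c(C(=O)N[C@@H](C)C(=O)O)ccc1C(CC)(CC)c1ccc(OCS(=O)(=O)c2ccccc2)c(C)c1` gives 35500 nM and compound 3 `CCn1c(C(=O)N[C@H](C(=O)O)C(C)C)ccc1C(CC)(CC)c1ccc(OCS(=O)(=O)c2ccccc2)c(C)c1` gives 24500 nM. On these numbers compound 1 stands second highest of three, and all three lie within the scatter of one another: a 1.2-fold higher number from compound 1 to compound 2 (0.09 log units; within the scatter), a 1.2-fold lower number from compound 1 to compound 3 (0.07 log units; within the scatter) and a 1.4-fold lower number from compound 2 to compound 3 (0.16 log units; within the scatter).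

Compound 4 `CCn1c(C(=O)N[C@H](CC(=O)O)C(=O)O)ccc1C(CC)(CC)c1ccc(OCS(=O)(=O)c2ccccc2)c(C)c1` extends this series. 1,2-dicarboxyethyl in place of 1-(hydroxymethyl)cyclopropyl on an amide-type nitrogen The steps from compound 1 to compound 2 and from compound 1 to compound 3 bear directly on this change, since each also exchanged the same 1-(hydroxymethyl)cyclopropyl for a carboxy-bearing group on the amide-type nitrogen, and neither moved beyond the scatter. The second carboxy group of the 1,2-dicarboxyethyl is not covered by any measured step. Compound 4 is therefore expected to show no step beyond the scatter, a 1.0-fold higher number from compound 1 to compound 4 (0.02 log units; within the scatter), with the range kept broad for the untested second acid. Compound 4 is estimated at 30000 nM, between 12000 nM and 75000 nM.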

Compound 4, half-maximal inhibitory concentration: > 50000 nM
Compound 4 ended at the assay's limit (the forecaster's own chance of this, stated with the estimate: 15%); middle value at least 1.6-fold (0.22 log units) away from the limit.
By their numbers in this assay, from the lowest: compounds 3, 1 and 2 (each within the scatter of the next). At a limit, above all of these: compound 4.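

In this assay compound 4 gives > 50000 nM, which is a limit of the assay and not a number. The steps to it are an at least 1.7-fold higher number from compound 1 to compound 4 (0.23 log units; that floor lies within the scatter) and an at least 2.0-fold higher number from compound 3 to compound 4 (0.30 log units; that floor lies within the scatter) and an at least 1.4-fold higher number from compound 2 to compound 4 (0.14 log units; that floor lies within the scatter) and so give floors only, each within the scatter, which leaves the true size of the change unread. For the compounds shown here, at the amide-type nitrogen, the 1-(hydroxymethyl)cyclopropyl, 1-carboxyethyl and 1-carboxy-2-methylpropyl groups all gave readable values, while the 1,2-dicarboxyethyl group is the first here to reach the limit: the limit of > 50000 nM in this assay, at which 1 of the 4 values shown sits.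

On these data alone, how far past that limit compound 4 lies stays open, as does whether the second carboxylic acid alone is tied to this result. Also open, as far as these compounds go, is whether a longer chain such as 1,3-dicarboxypropyl, or a primary amide in place of the second carboxylic acid, would reach the same limit.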